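Furan to pyrrole on the shared core of compound 2

This account rests on a few compounds, and the source may have more. Where it says the series, first, only, none or still open, it means among the compounds named here.

Compound 1, with structure `OC[C@H]1O[C@@H](n2cc(F)c3c(-c4ccccc4)ncnc32)[C@H](O)[C@@H]1O`, was tested in a functional assay on HL-60 cells (Homo sapiens) for cytotoxicity, read by XTT assay, with a stated time of 3 days; a lower number here means a stronger inhibitor, a higher number a weaker inhibitor. In this assay compound 1 gives only a limit, > 40000 nM, rather than a number. Compound 2, with structure `OC[C@H]1O[C@@H](n2cc(F)c3c(-c4ccco4)ncnc32)[C@H](O)[C@@H]1O`, gives 1200 nM in this assay. The step from phenyl to furan-2-yl brought an at least 33-fold lower number from compound 1 to compound 2 (1.52 log units; beyond the scatter), and the limit of > 40000 nM in this assay, at which 1 of the 2 values shown sits, is where compound 1 sits. Within the data shown here, compound 2 therefore holds the only numerical value shown, with the one other value being a limit.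

Compound 3, with structure `OC[C@H]1O[C@@H](n2cc(F)c3c(-c4ccc[nH]4)ncnc32)[C@H](O)[C@@H]1O`, differs from compound 2 in one place: 1H-pyrrol-2-yl in place of furan-2-yl on an aromatic carbon. Among the measured compounds shown here, no measured step swaps one five-membered ring for another; the single step measured, from compound 1 to compound 2, replaced a six-membered ring by a five-membered one. With nothing closer to lean on, the expected step in this assay for compound 3 is a 1.3-fold higher number from compound 2 to compound 3 (0.10 log units; within the scatter), within the usual scatter. Compound 3 is thus estimated at 1500 nM, with a range from 400 nM to 6000 nM.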

Compound 3, half-maximal inhibitory concentration: 3300 nM
Estimate against measurement, compound 3: 2.2-fold (0.34 log units) below; measured number inside the range.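

The ring atom matters at this position, and not only the ring size: on the same aromatic carbon, 1H-pyrrol-2-yl in place of furan-2-yl gives a 2.8-fold higher number from compound 2 to compound 3 (0.44 log units; beyond the scatter) in this assay. The five-membered ring still keeps a clear advantage over phenyl, with an at least 12-fold lower number from compound 1 to compound 3 (1.08 log units; beyond the scatter), so both five-membered rings give a lower number than the six-membered one. That comparison rests on a value for compound 1 that is a limit and not a number: the limit of > 40000 nM in this assay, at which 1 of the 3 values shown sits.

The change swaps a hydrogen-bond acceptor for a hydrogen-bond donor along with oxygen for nitrogen, and this single step cannot separate those two differences. From the compounds shown here alone, it remains open how thiophen-2-yl, with sulfur as its ring atom, or a smaller group such as an amine on this carbon would compare.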